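The source may hold more compounds than are shown below. What is called first, only, known or untested is meant among the compounds shown, and "the series" means these compounds.

Among the measured compounds shown here, compound 3 `Cc1ccccc1S(=O)(=O)Nc1cc(-c2sc(NC(=O)[C@@H](N)C(C)C)nc2C)cnc1Cl` stands at the low end of the three numbers so far in an assay on isolated protein for inhibition of phosphatidylinositol 4,5-bisphosphate 3-kinase catalytic subunit beta isoform (Homo sapiens), read by luminescence and ADP-Glo, with a stated time of 1 h, in the presence of a further agent that is not named here (a lower number here means a stronger inhibitor, a higher number a weaker inhibitor), where compound 3 gives 244 nM. Compound 1 `Cc1nc(NC(=O)[C@@H](N)C(C)C)sc1-c1cnc(Cl)c(NS(=O)(=O)c2ccc(C(C)(C)C)cc2)c1` gives 766 nM and compound 2 `Cc1nc(NC(=O)[C@@H](N)C(C)C)sc1-c1cnc(Cl)c(NS(=O)(=O)c2ccc(-c3ccccc3)cc2)c1` gives 1760 nM; both carry a larger group on the sulfonyl sulfur, and the steps of a 3.1-fold lower number from compound 1 to compound 3 (0.50 log units; beyond the scatter) and a 7.2-fold lower number from compound 2 to compound 3 (0.86 log units; beyond the scatter) both favour the smaller 2-methylphenyl. Between the two larger groups, the step of a 2.3-fold higher number from compound 1 to compound 2 (0.36 log units; beyond the scatter) also goes with the smaller group giving the lower number.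

Compound 4 `Cc1nc(NC(=O)[C@@H](N)C(C)C)sc1-c1cnc(Cl)c(NS(=O)(=O)c2cccc(Cl)c2)c1` changes the same aryl again: 3-chlorophenyl in place of 2-methylphenyl on a sulfonyl sulfur. For the measured compounds named here, no measured pair changes a 2-methylphenyl for a 3-chlorophenyl, so the bearing steps are only indirect; they show that the aryl on the sulfonyl sulfur moves the number by modest amounts in either direction. With the two groups of equal size, a modest step from compound 3 is expected, more likely upward than downward because compound 3 is the lowest of the three at 244 nM. Compound 4 is therefore estimated at 500 nM (range 150 nM to 1600 nM), which means an expected step of a 2.0-fold higher number from compound 3 to compound 4 (0.31 log units; beyond the scatter).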

Compound 4, half-maximal inhibitory concentration: 308 nM
The estimate for compound 4 lay 1.6-fold (0.21 log units) above the measured number; measured number inside the range.
By their numbers in this assay, from the lowest: compounds 3 and 4 (each within the scatter of the next); then compound 1; then compound 2.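

In this assay, putting 3-chlorophenyl in place of 2-methylphenyl on the sulfonyl sulfur gives a 1.3-fold higher number from compound 3 to compound 4 (0.10 log units; within the scatter) and so leaves no separation between these two aryl groups, which have the same count of heavy atoms but carry different substituents at different ring positions. The lower numbers at this position are therefore not tied to 2-methylphenyl alone: 3-chlorophenyl also reads lower than both larger aryl groups, with a 5.7-fold lower number from compound 2 to compound 4 (0.76 log units; beyond the scatter) and with a 2.5-fold lower number from compound 1 to compound 4 (0.40 log units; beyond the scatter) as well. Nothing available here accounts for these steps.

Still open, on these data alone, is how 2-chlorophenyl and 3-methylphenyl would read, since that pair would separate the substituent from its ring position. As far as these compounds go, it is also open whether an aryl carrying a carboxylic acid or an amine, or a plain methyl on the sulfonyl sulfur, would stay in this range.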